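Bisaziridinyl quinones: side-chain variation on the shared core

The source may report more compounds than this note shows. Statements on the series, on what has been measured and on what is new or still open speak of the compounds shown alone.

Measured compounds in a functional assay on L1210 cells (Mus musculus), with a stated time of 1 days; a higher number here means a more potent compound, by a factor of ten per unit of this negative logarithm, a lower number a less potent compound:
compound 1 `O=C1C(CCO)=C(N2CC2)C(=O)C(CCO)=C1N1CC1` gives 5.93
compound 2 `COCCC1=C(N2CC2)C(=O)C(C)=C(N2CC2)C1=O` gives 5.19
compound 3 `COCCC1=C(N2CC2)C(=O)C(CCOC)=C(N2CC2)C1=O` gives 5.18

Compound 2 stands second highest of the three. Its nearest neighbour is compound 3, whose value lies within the scatter of it; compound 1 is the furthest, and the values of compound 1 and compound 2 differ by more than the scatter.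

Compound 4 `CC1=C(N2CC2)C(=O)C(CCC(=O)N(C)C)=C(N2CC2)C1=O` is not yet measured. It differs from compound 2 as follows: dimethylcarbamoyl in place of methoxy on a saturated chain carbon, two bonds along the chain from a double-bonded ring carbon.

Going by the values given here, only one measured step touches the same side chain, a number 0.01 log units lower from compound 2 to compound 3 (within the scatter), and it is within the scatter. Among the compounds with values here, no measured pair exchanges a methoxy for a dimethylcarbamoyl, so the present change is unanchored; the one chain step available shows that lengthening the chain leaves this assay unchanged. For compound 4 a step of a number 0.11 log units higher from compound 2 to compound 4 (within the scatter) is therefore expected, not beyond the scatter. Compound 4 is expected at 5.3, in the range 4.8 to 5.9.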

Compound 4, logarithm of the reciprocal of the active concentration, log(1/C): 5.09
The estimate for compound 4 lay 0.21 log units above the measured number; the measured number falls inside the stated range.
By their numbers in this assay, from the lowest: compounds 4, 3 and 2 (each within the scatter of the next); then compound 1.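

In this assay the step of a number 0.10 log units lower from compound 2 to compound 4 (within the scatter) goes with dimethylcarbamoyl in place of methoxy on a saturated chain carbon, two bonds along the chain from a double-bonded ring carbon. Going by these compounds alone, this position therefore accepts a 2-(dimethylcarbamoyl)ethyl chain, an amide-bearing end group not seen in the earlier compounds, without a shift beyond the scatter. No available measurement accounts for this result.

As far as these compounds go, a carboxylic acid or a primary amine at the end of this chain remains open, as does a longer chain carrying the dimethylcarbamoyl group. Also open, from the compounds shown here alone, is what a single 2-hydroxyethyl chain would give with the methyl group kept, since compound 1 differs from compound 2 in more than one place.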